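Thiophene Isomer Swap on a Methylamino Nucleoside Core

The compounds below may be only part of what the source reports. "The series", "measured", "known", "first", "only" and "open" are said of these compounds alone.

Measured compounds:
compound 1 `COc1ncnc2c1c(-c1ccsc1)cn2[C@@H]1O[C@H](CO)[C@@H](O)[C@H]1O`: 140 nM
compound 2 `COc1ncnc2c1c(-c1cccs1)cn2[C@@H]1O[C@H](CO)[C@@H](O)[C@H]1O`: 440 nM
compound 3 `CNc1ncnc2c1c(-c1cccs1)cn2[C@@H]1O[C@H](CO)[C@@H](O)[C@H]1O`: > 20000 nM (a limit)

In a functional assay on HCT-116 cells (Homo sapiens), read by MTT assay, with a stated time of 72 h (a higher number here means a weaker inhibitor, a lower number a stronger inhibitor), compound 1 gives 140 nM and compound 2 gives 440 nM. For compound 3 this assay reports only a limit, > 20000 nM. Two changes connect these compounds. The step of a 3.1-fold lower number from compound 2 to compound 1 (0.50 log units; beyond the scatter) comes with the change (thiophen-3-yl in place of thiophen-2-yl on an aromatic carbon). The step of an at least 45-fold higher number from compound 2 to compound 3 (1.65 log units; beyond the scatter) comes with the change in the core (methylamino in place of methoxy on an aromatic carbon); here compound 3 stands at the limit of > 20000 nM in this assay, at which 1 of the 3 values shown sits.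

Compound 4 `CNc1ncnc2c1c(-c1ccsc1)cn2[C@@H]1O[C@H](CO)[C@@H](O)[C@H]1O` has not been measured in this assay. It differs from compound 3 by thiophen-3-yl in place of thiophen-2-yl on an aromatic carbon, the same change that separates compound 2 from compound 1. Should that change act on compound 3 as it did before, compound 4 is expected to give 25000 nM, with a likely range from 6000 nM to 100000 nM. For compound 4 the expected step is a step that the limit leaves unreadable from compound 3 to compound 4, resting on the earlier step of a 3.1-fold lower number from compound 2 to compound 1 (0.50 log units; beyond the scatter). Since compound 3 is known only as a limit, the estimate for compound 4 may itself turn out to be a limit.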

Compound 4, half-maximal inhibitory concentration: > 20000 nM
Compound 4 was reported as a limit (the forecaster's own chance of this, stated with the estimate: 60%); the middle value lies beyond the limit too.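

In this assay compound 4 gives > 20000 nM, which is a limit. Methylamino in place of methoxy again goes with a large loss on the thiophen-3-yl core, an at least 140-fold higher number from compound 1 to compound 4 (2.15 log units; beyond the scatter), so the direction of this change carries from one core to the other, though its size on each core stays undetermined: the same change on two cores in this assay, an at least 45-fold higher number (1.65 log units; beyond the scatter) from compound 2 to compound 3 and an at least 140-fold higher number (2.15 log units; beyond the scatter) from compound 1 to compound 4; the limit leaves it open whether they differ. The step from thiophen-2-yl to thiophen-3-yl on the methylamino core cannot be read, so it remains unknown whether the gain seen with methoxy carries over to this core, and the comparison here rests on: the limit of > 20000 nM in this assay, at which 2 of the 4 values shown sit.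

The compounds shown leave open whether the loss is specific to methylamino or would also appear with an unsubstituted amine, a dimethylamino group or an ethoxy group in place of methoxy. They also leave open how a furan-3-yl or phenyl group would behave in place of the thiophene on the methoxy core.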